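The source may report more compounds than this note shows. Statements on the series, on what has been measured and on what is new or still open speak of the compounds shown alone.

Measured compounds:
Compound 1 `Cn1cncc1C1CCCc2c(NS(C)(=O)=O)cccc21`: in an assay on isolated protein for binding affinity to Alpha-1A adrenergic receptor (Rattus norvegicus), read by radioligand binding (on this read-out higher numbers stand for weaker inhibition and lower numbers for stronger inhibition), compound 1 gives < 10000 nM, which is a limit of the assay and not a number.
Compound 2 `CCS(=O)(=O)Nc1cccc2c1CCCC2c1c[nH]c(C)n1`: in this assay compound 2 gives 794 nM.

Going by the values given here, compound 2 holds the only numerical value in this small set; the one other result, that of compound 1, sits as a limit of < 10000 nM in this assay, at which 1 of the 2 values shown sits, and cannot be set against it. Compound 3 `CCS(=O)(=O)Nc1cccc2c1CCCC2CNC` has not yet been measured. It differs from compound 2 in a single place: (methylamino)methyl in place of 2-methyl-1H-imidazol-4-yl on a saturated ring carbon. Among the compounds with values here, no step between measured compounds is available to size such a change, so there is nothing in these data to lean on. The account therefore expects a step from compound 2 to compound 3 of a 2.5-fold higher number from compound 2 to compound 3 (0.40 log units; beyond the scatter), toward weaker binding but modest, and holds it loosely. For compound 3 the estimate in this assay is 2000 nM, with a range from 300 nM to 15000 nM; a result reported only as a limit is a real possibility.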

Compound 3, inhibition constant: 1380 nM
Beside the measured number, compound 3's estimate is 1.4-fold (0.16 log units) above it, within the range that was stated.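

On a saturated ring carbon, (methylamino)methyl in place of 2-methyl-1H-imidazol-4-yl gives a 1.7-fold higher number from compound 2 to compound 3 (0.24 log units; within the scatter) in this assay and so the two compounds cannot be told apart on this read-out. Going by these compounds alone, this is the first step available at this place, and it shows that, in this one pair, the five-membered aromatic ring can give way to a group with no ring without a difference beyond the scatter. Nothing measured here accounts for the size of this step.

On these data alone, whether this tolerance extends to other groups at the same carbon remains open, for instance a primary amine, a carboxylic acid or a longer chain such as (ethylamino)methyl. A single pair also cannot show whether the same exchange would give a similar step on a different core.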